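This account rests on a few compounds, and the source may have more. Where it says the series, first, only, none or still open, it means among the compounds named here.

Working notes on the series.

Compound 1, `CSc1ncnc2c1ncn2C1CCCCO1`, is the simpler of the two measured structures. In an assay on isolated protein for binding affinity to Equilibrative nucleoside transporter 1 (Homo sapiens) (on this read-out higher numbers stand for weaker inhibition and lower numbers for stronger inhibition), compound 1 gives 275000 nM. Compound 2, `Nc1nc(SCc2ccc(Br)cc2)c2ncn([C@@H]3O[C@H](CO)[C@@H](O)[C@H]3O)c2n1`, carries the shared core with a sugar and a substituted sulfur, and in this assay compound 2 gives 813 nM. Among the compounds with values here, on the two numbers at hand, compound 2 stands lowest, and the gap to compound 1, its only neighbour, lies well beyond the scatter of repeat measurements. Within the data shown here, no pair of measured compounds differing in a single place is available, so there is no measured step to lean on.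

Compound 3, `CC(=O)c1cc(Cl)ccc1Sc1nc(N)nc2c1ncn2[C@@H]1O[C@H](CO)[C@@H](O)[C@H]1O`, differs from compound 2 in one place: 2-acetyl-4-chlorophenyl in place of 4-bromobenzyl on a sulfur. With no measured step of this kind in the set, only a rough expectation is possible. The step of a 1.8-fold higher number from compound 2 to compound 3 (0.27 log units; within the scatter) is expected to be small, toward somewhat weaker inhibition, and may well sit inside the scatter. For compound 3 in this assay the estimate is 1500 nM, with a plausible range from 300 nM to 8000 nM.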

Compound 3, half-maximal inhibitory concentration: 14500 nM
Compound 3: the middle estimate sits 9.7-fold (0.99 log units) below what was measured, and the stated range ends below it.
By their numbers in this assay, from the lowest: compound 2; then compound 3; then compound 1.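

In this assay, the group on this sulfur is a sensitive point of change: an 18-fold higher number from compound 2 to compound 3 (1.25 log units; beyond the scatter), with 2-acetyl-4-chlorophenyl in place of 4-bromobenzyl and the sugar and the rest of the shared core unchanged. Within the data shown here, this is the first measured step that differs in one place, and it shows that this exchange alone moves the read-out toward weaker inhibition by a margin beyond the scatter, which the earlier pair, differing in more than one place, could not show. No measurement at hand accounts for the size of this step.

The exchange alters several features at once, so the compounds shown leave open whether the step follows from the loss of the 4-bromobenzyl group, the presence of the acetyl group, or the chlorine in place of the bromine. Also open, on these data alone, is how a plain benzyl, a 4-bromophenyl or a 4-chlorophenyl group on this sulfur would read, and whether an amine or a carboxylic acid in place of the acetyl group would shift the number in either direction.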